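From cyclopentyl to 4-hydroxy-4-methylcyclohexyl in compound 4

The compounds below may be only part of what the source reports. "The series", "measured", "known", "first", "only" and "open" are said of these compounds alone.

Among the compounds with values here, in a functional assay on CAL-51 cells (Homo sapiens) for antiproliferative activity, read by luminescence and CellTiter-Glo, with a stated time of 3 days (a higher number here means a weaker inhibitor, a lower number a stronger inhibitor), compound 3 (`COc1cc(C(=O)N(C)C)ccc1Nc1nc(OC2CCCC2)c2cc[nH]c2n1`) gives 497 nM and stands highest of the three numbers so far, while compound 2 (`COc1cc(C(=O)N(C)C)ccc1Nc1nc(O[C@H]2CCOC(C)(C)C2)c2cc[nH]c2n1`) gives 131 nM on the same read-out. Compound 4 (`COc1cc(C(=O)N(C)C)ccc1Nc1nc(O[C@H]2CC[C@](C)(O)CC2)c2cc[nH]c2n1`) carries 4-hydroxy-4-methylcyclohexyl in place of cyclopentyl on an oxygen on an aromatic ring. Within the data shown here, the one measured step at this place is a 3.8-fold higher number from compound 2 to compound 3 (0.58 log units; beyond the scatter) and it is modest, with cyclopentyl entering for 2,2-dimethyloxan-4-yl. Compound 1 (`C[C@@H](Oc1cc(C(=O)N(C)C)ccc1Nc1nc(O[C@H]2CC[C@@](C)(O)CC2)c2cc[nH]c2n1)C(F)(F)F`) carries a group of the same name with different stereochemistry and also differs elsewhere, so its 24 nM is only a loose guide. In this assay a modest step to a lower number is therefore expected (a 5.0-fold lower number from compound 3 to compound 4 (0.70 log units; beyond the scatter)). Compound 4 is estimated at 100 nM within an expected range from 30 nM to 350 nM in this series.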

Compound 4, half-maximal inhibitory concentration: 69 nM
The estimate for compound 4 lay 1.4-fold (0.16 log units) above the measured number; the measured number falls inside the stated range.
By their numbers in this assay, from the lowest: compound 1; then compounds 4 and 2 (each within the scatter of the next); then compound 3.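

In this assay, the position on the oxygen takes 4-hydroxy-4-methylcyclohexyl well, with a 7.2-fold lower number from compound 3 to compound 4 (0.86 log units; beyond the scatter) against cyclopentyl. Against 2,2-dimethyloxan-4-yl the same group gives a 1.9-fold lower number from compound 2 to compound 4 (0.28 log units; within the scatter), so these two groups cannot be told apart here, while both stand clear of cyclopentyl. Nothing on hand explains the gain over cyclopentyl.

Still open, as far as these compounds go, is whether 4-methylcyclohexyl, lacking the hydroxyl, would read with compound 4 or with compound 3. A 4-aminocyclohexyl group on this oxygen would test whether an amine can stand in for that hydroxyl.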